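A few compounds are considered here, and "the series" means these few. Any claim that something is new, unique, unknown or untested is made for them only; others in the source may bear on it.

Measured in a functional assay on B16-F10 cells (Mus musculus) for antiproliferative activity, read by MTT assay, with a stated time of 72 h; on this read-out higher numbers stand for weaker inhibition and lower numbers for stronger inhibition:
- Compound 1 `CCCCCCCNC[C@@H]1OC[C@H](N)[C@@H]1O`: > 128000 nM, a limit of the assay and not a number.
- Compound 2 `CCCCCCCCCCCCNC[C@@H]1OC[C@H](N)[C@H]1O`: 58100 nM.

Within the data shown here, compound 2 holds the only actual number so far, and the one other result is a limit, as the limit of > 128000 nM in this assay, at which 1 of the 2 values shown sits, records. Compound 2 therefore stands as the sole numerical reference point in this assay.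

Compound 3 `CCCCCCCCCCCCCCNC[C@@H]1OC[C@H](N)[C@H]1O` departs from compound 2 by a single change, (ethyl in place of hydrogen on a saturated chain carbon, ten or more bonds along the chain from an amine nitrogen), which places ethyl in place of hydrogen on a saturated chain carbon, ten or more bonds along the chain from an amine nitrogen.

Among the measured compounds shown here, no measured step exists to size this change, so the expectation rests on compound 2 at 58100 nM alone. The expected change is a 1.9-fold lower number from compound 2 to compound 3 (0.29 log units; within the scatter), a small move towards stronger inhibition, roughly the size of the usual scatter. For compound 3 the estimated value is 30000 nM, with an expected range of 9000 nM to 90000 nM.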

Compound 3, half-maximal inhibitory concentration: 64300 nM
Estimate against measurement, compound 3: 2.1-fold (0.33 log units) below; low and high end bracket the measured number.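

The step of a 1.1-fold higher number from compound 2 to compound 3 (0.04 log units; within the scatter) gives the series its first measured size for ethyl in place of hydrogen on a saturated chain carbon, ten or more bonds along the chain from an amine nitrogen. In this assay compound 2 and compound 3 cannot be told apart, so at this place on the chain the added ethyl leaves no difference that can be read. Compound 1 and compound 2 differ in more than one place and gave no such reading of a single change.

From the compounds shown here alone, what a longer chain, or a hydroxyl or a carboxylic acid at this same place on the chain, would give remains open. Compound 1 still stands as a limit and not a number, so no step to it can be sized: the limit of > 128000 nM in this assay, at which 1 of the 3 values shown sits.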